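The compounds below may be only part of what the source reports. "The series", "measured", "known", "first", "only" and "open" are said of these compounds alone.

Three compounds share one core and differ only in the aryl group on the amine nitrogen in a ring. Compound 1 `CC1CC(=O)N(CC(=O)N2CCN(c3ccc(F)cc3)CC2)C1=O` carries a 4-fluorophenyl there; in a functional assay on the whole organism (strain CD1) with Mus musculus as the target, in the maximal electroshock model, with a stated time of 4 h (a lower number here means that less compound is needed, a higher number that more compound is needed for the effect), compound 1 gives 100 mg/kg. Compound 2 `CC1CC(=O)N(CC(=O)N2CCN(c3ccc(Cl)c(Cl)c3)CC2)C1=O` carries a 3,4-dichlorophenyl, and in this assay compound 2 gives 100 mg/kg. Compound 3 `CC1CC(=O)N(CC(=O)N2CCN(c3cccc(C(F)(F)F)c3)CC2)C1=O` carries a phenyl bearing a trifluoromethyl group, and in this assay compound 3 gives 100 mg/kg. Compound 2 thus stands level with compounds 1 and 3, within the scatter of both. Among the measured compounds shown here, the single measured step, no change at the digits printed from compound 1 to compound 2 (within the scatter), shows that exchanging one aryl group for another left the dose unchanged. Compound 4 `CC1CC(=O)N(CC(=O)N2CCN(c3cccc(Cl)c3)CC2)C1=O` is the next compound: hydrogen in place of chloro on an aromatic carbon. For the measured compounds named here, no measured step removes a chloro group, yet the one comparison that bears on an aryl change, no change at the digits printed from compound 1 to compound 2 (within the scatter), together with the level values of all three compounds, suggests no step beyond the scatter. The step from compound 2 to compound 4 is expected to be no change at the digits printed from compound 2 to compound 4 (within the scatter). Compound 4 is therefore estimated at 100 mg/kg, with a range from 50 mg/kg to 200 mg/kg.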

Compound 4, minimum effective dose: 300 mg/kg
For compound 4 the middle estimate is 3.0-fold (0.48 log units) below the measured one; the measured number lies above the stated range.
By their numbers in this assay, from the lowest: compounds 1, 2 and 3 (each within the scatter of the next); then compound 4.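

In this assay the aryl group does matter: taking away the chloro group ortho to a chloro group and para to a large group, which turns 3,4-dichlorophenyl into 3-chlorophenyl, gives a 3.0-fold higher number from compound 2 to compound 4 (0.48 log units; beyond the scatter) and so calls for more compound. Placing chloro where trifluoromethyl stood gives a 3.0-fold higher number from compound 3 to compound 4 (0.48 log units; beyond the scatter) and the exchange of the whole aryl group gives a 3.0-fold higher number from compound 1 to compound 4 (0.48 log units; beyond the scatter) in the same direction, so 3-chlorophenyl stands apart from the three aryl groups that were level. A change of one heavy atom can therefore move the dose, although the exchange of 4-fluorophenyl for 3,4-dichlorophenyl did not.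

Nothing shown explains this shift. Open, on these data alone, is whether a bromo, methyl or methoxy group on that same aromatic carbon would restore the lower dose.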